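Methyl in Place of Trifluoromethyl: Expected Effect on Compound 4

The source may hold more compounds than are shown below. What is called first, only, known or untested is meant among the compounds shown, and "the series" means these compounds.

Of the compounds shown here, three from this series have been measured in a functional assay on Huh-7 cells (Homo sapiens) for inhibition, read by sulforhodamine B assay, with a stated time of 72 h; a higher number here means a weaker inhibitor, a lower number a stronger inhibitor. Compound 1 `CC(c1ccc(-c2ccccc2)c(F)c1)c1nnc2n1N=C(c1ccc(OC(F)(F)F)cc1)CS2` gives 8400 nM. Compound 2 `COc1ccc(C2=Nn3c(nnc3C(C)c3ccc(-c4ccccc4)c(F)c3)SC2)cc1` gives 4300 nM. Compound 3 `CC(C)Cc1ccc(C(C)c2nnc3n2N=C(c2ccc(OC(F)(F)F)cc2)CS3)cc1` gives 3600 nM. Compound 2 differs from compound 1 only by methyl in place of trifluoromethyl on an oxygen on an aromatic ring, and the step of a 2.0-fold lower number from compound 1 to compound 2 (0.29 log units; within the scatter). Compound 3 differs from compound 1 in more than one place; the difference between the two cores is not broken down here, and their two values stand beyond the scatter of each other.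

Compound 4 `COc1ccc(C2=Nn3c(nnc3C(C)c3ccc(CC(C)C)cc3)SC2)cc1` has not yet been measured in this assay. It differs from compound 3 by methyl in place of trifluoromethyl on an oxygen on an aromatic ring. Among the compounds with values here, this is the same change, at a place described in the same words, as the one that turned compound 1 into compound 2. Because a 2.0-fold lower number from compound 1 to compound 2 (0.29 log units; within the scatter), a step of similar size is expected here, a 1.6-fold lower number from compound 3 to compound 4 (0.21 log units; within the scatter), resting on that single earlier example alone. In this assay compound 4 is therefore estimated at 2200 nM, with a plausible range from 900 nM to 5500 nM.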

Compound 4, half-maximal inhibitory concentration: 3700 nM
For compound 4 the middle estimate is 1.7-fold (0.23 log units) below the measured one; measured number inside the range.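

In this assay, the exchange of trifluoromethoxy for methoxy on the core of compound 3 gives a 1.0-fold higher number from compound 3 to compound 4 (0.01 log units; within the scatter), so this second example of the change also stays within the usual scatter of repeated measurements. Set beside the earlier example, the step on the second core cannot be told apart from the first: the same change on two cores in this assay, a 2.0-fold lower number (0.29 log units; within the scatter) from compound 1 to compound 2 and a 1.0-fold higher number (0.01 log units; within the scatter) from compound 3 to compound 4, 2.0-fold (0.30 log units) apart, within the scatter of two such steps This shows that, across these two cores, the change produced no step beyond the scatter and no detectable dependence on the core, but it does not show that the change has any real effect on either core, nor that the two steps are truly equal, and two examples cannot establish a rule for the whole series.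

The compounds shown carry only methyl or trifluoromethyl on an oxygen on an aromatic ring, so what an ethyl group or a longer chain would do there remains open. Also open, going by these compounds, is whether the same flat result would hold on a core bearing an amine or a carboxylic acid.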